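This account rests on a few compounds, and the source may have more. Where it says the series, first, only, none or still open, it means among the compounds named here.

The measured compounds in an ADME assay on NIH3T3 cells (Mus musculus) for cytotoxicity, read by MTT assay, with a stated time of 24 h; a higher number here means a weaker inhibitor, a lower number a stronger inhibitor:
Compound 1 `O=C(CSc1nnc(-c2ccncc2)o1)N/N=C/c1ccc(F)cc1` gives 170000 nM.
Compound 2 `O=C(CSc1nnc(-c2ccncc2)o1)N/N=C/c1ccc(O)cc1` gives 158000 nM.
Compound 3 `O=C(CSc1nnc(-c2ccncc2)o1)N/N=C/c1ccccc1O` gives 155000 nM.

Compound 2 holds the second highest of the three numbers; its nearest neighbour is compound 3, a 1.0-fold lower number from compound 2 to compound 3 (0.01 log units; within the scatter), and its furthest is compound 1, a 1.1-fold lower number from compound 1 to compound 2 (0.03 log units; within the scatter), both within the scatter. Compound 4 `O=C(CSc1nnc(-c2ccncc2)o1)N/N=C/c1ccc(Cl)cc1Cl` is not yet measured and differs from compound 2 as follows: 2,4-dichlorophenyl in place of 4-hydroxyphenyl on a carbon with a double bond to nitrogen. Among the measured compounds shown here, no measured step replaces hydroxy with chloro; the closest comparison is a 1.1-fold lower number from compound 1 to compound 2 (0.03 log units; within the scatter), a swap between hydroxy and a halogen that stayed within the scatter, as did a 1.1-fold lower number from compound 1 to compound 3 (0.04 log units; within the scatter). Each change on this ring so far left the number unmoved, so no step beyond the scatter is expected in this assay. Compound 4 is therefore estimated at 150000 nM with a range of 60000 nM to 350000 nM, an expected step of a 1.1-fold lower number from compound 2 to compound 4 (0.02 log units; within the scatter).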

Compound 4, half-maximal inhibitory concentration: 221000 nM
Compound 4: middle estimate off by 1.5-fold (0.17 log units), on the low side; the measured number falls inside the stated range.
By their numbers in this assay, from the lowest: compounds 3, 2, 1 and 4 (each within the scatter of the next).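

Swapping in the 2,4-dichlorophenyl group at this position extends the flat picture in this assay to a ring carrying two chlorines (a 1.4-fold higher number from compound 2 to compound 4 (0.15 log units; within the scatter)), and the same holds against the other hydroxy compound (a 1.4-fold higher number from compound 3 to compound 4 (0.15 log units; within the scatter)) and the fluoro compound (a 1.3-fold higher number from compound 1 to compound 4 (0.11 log units; within the scatter)). Even a ring with no hydrogen-bond donor or acceptor stays within the scatter of the hydroxyphenyl rings. No measurement shown offers an explanation for this. From the compounds shown here alone, all four compounds keep a substituted phenyl ring here, so it remains open whether an amine or a carboxylic acid on that ring, or a longer chain in its place, would shift the number.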